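A few compounds are considered here, and "the series" means these few. Any claim that something is new, unique, unknown or untested is made for them only; others in the source may bear on it.

In a functional assay on NCI-H226 cells (Homo sapiens) for inhibition, read by MTT assay, with a stated time of 48 h, tested at 10 uM (on this read-out lower numbers stand for less inhibition and higher numbers for more inhibition at the one concentration tested (going by the name of the read-out)), the three measured compounds of the series stand as follows. Compound 1 `Cc1ccc(Nc2cc(NC(=O)Nc3c(Cl)cccc3Cl)ncn2)cc1F` gives 40.7%, compound 2 `COc1cc(Nc2cc(NC(=O)Nc3c(Cl)cccc3Cl)ncn2)cc(OC)c1` gives 60%, and compound 3 `COc1cc(NC(=O)Nc2cc(Nc3ccc(C)c(F)c3)ncn2)cc(OC)c1` gives 39.7%. Compound 3 stands lowest of the three numbers: compound 1 is nearest, its number higher by a gap within the scatter, so the two cannot be ordered against each other; compound 2 is furthest, its number higher by a gap beyond the scatter.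

Compound 4 `COc1cc(NC(=O)Nc2cc(Nc3ccc(Br)cc3OC)ncn2)cc(OC)c1` has not been measured. Against compound 3 the change is 4-bromo-2-methoxyphenyl in place of 3-fluoro-4-methylphenyl on a nitrogen on an aromatic ring. For the measured compounds named here, no step between two measured compounds tests 4-bromo-2-methoxyphenyl against 3-fluoro-4-methylphenyl on a nitrogen on an aromatic ring, so no direction can be read from the series, and the estimate is kept near compound 3 with a wide range. The step from compound 3 to compound 4 is expected to be a number 2.3 percentage points higher from compound 3 to compound 4 (within the scatter), not beyond the scatter. Compound 4 is estimated to give 42% in this assay, between 20% and 65%.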

Compound 4, a percentage reported as inhibition, at one concentration (the size of the read-out at that concentration, not a potency): 25.7%
For compound 4 the middle estimate is 16.3 percentage points above the measured one; the measured number falls inside the stated range.
By their numbers in this assay, from the lowest: compound 4; then compounds 3 and 1 (each within the scatter of the next); then compound 2.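

The aryl group on the nitrogen is not a silent place in this assay: 4-bromo-2-methoxyphenyl in place of 3-fluoro-4-methylphenyl gives a number 14 percentage points lower from compound 3 to compound 4 (beyond the scatter), a modest step but the series' only one at this position, with the rest of the molecule unchanged. The entering group differs from the leaving group in several features at once, including its methoxy group, its bromine and one hydrogen-bond acceptor, so this single step cannot assign the drop to any one of them. No measurement bears on why the number falls.

Which of these features carries the step remains open, as does whether a simple phenyl or a group such as an amine or a carboxylic acid on this aryl ring would restore or exceed the number of compound 3. Also open, going by these compounds, is whether the same change would give a step of similar size on the core of compound 2.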